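Shortening the chain of compound 1

The source may hold more compounds than are shown below. What is called first, only, known or untested is meant among the compounds shown, and "the series" means these compounds.

Compound 1 `Nc1ncnc2c1c(-c1cnc3[nH]ccc3c1)nn2CCCCCCCCC(=O)NO` gives 11200 nM
Compound 2 `Nc1nc2cc(-c3nn(CCCCCCCCCC(=O)NO)c4ncnc(N)c34)ccc2o1` gives 14100 nM

For the measured compounds named here, in a functional assay on SK-HEP1 cells (Homo sapiens) for inhibition, read by MTT assay, with a stated time of 72 h (on this read-out higher numbers stand for weaker inhibition and lower numbers for stronger inhibition), compound 1 and compound 2 lie within the usual scatter of each other, so compound 1 stands level with the only other compound measured so far. Neither compound shows strong inhibition apart from the other.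

Compound 3 `Nc1ncnc2c1c(-c1cnc3[nH]ccc3c1)nn2CCCCCCC(=O)NO` has not yet been measured. It departs from compound 1 by one change hydroxycarbamoyl in place of 2-(hydroxycarbamoyl)ethyl on a saturated chain carbon, six bonds along the chain from an aromatic nitrogen with hydroxycarbamoyl in place of 2-(hydroxycarbamoyl)ethyl on a saturated chain carbon, six bonds along the chain from an aromatic nitrogen. Going by the values given here, no measured pair isolates such a change, so the data offer no direct guide and any expectation stays loose.

A small move toward stronger inhibition is expected for this change (a 1.7-fold lower number from compound 1 to compound 3 (0.24 log units; within the scatter)) and no more than that. In this assay compound 3 is estimated at 6500 nM with an expected range from 2000 nM to 20000 nM overall.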

Compound 3, half-maximal inhibitory concentration: 14700 nM
The estimate for compound 3 lay 2.3-fold (0.35 log units) below the measured number; the measured number falls inside the stated range.
By their numbers in this assay, from the lowest: compounds 1, 2 and 3 (each within the scatter of the next).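

In this assay, hydroxycarbamoyl in place of 2-(hydroxycarbamoyl)ethyl on a saturated chain carbon, six bonds along the chain from an aromatic nitrogen, comes with a 1.3-fold higher number from compound 1 to compound 3 (0.12 log units; within the scatter) and so cannot be told apart from repeat measurement. This is the first pair shown that isolates a single change, and it indicates that, on the core of compound 1, the number holds level when the chain is cut back by this much. Nothing at hand bears on why the read-out stays level here.

From the compounds shown here alone, whether a much shorter chain, or a longer chain than that of compound 1, would move the number remains open. So does the outcome of putting a carboxylic acid or a primary amide in place of hydroxycarbamoyl at the chain end.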